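Second double bond in the side chain of compound 3

A few compounds are considered here, and "the series" means these few. Any claim that something is new, unique, unknown or untested is made for them only; others in the source may bear on it.

Compound 3 `CCCCCCCC/C=C\CCCCCCC/C(O)=C1/C(=O)[C@H](Cc2ccccc2)N(C(=O)OC(C)(C)C)C1=O` gives 1800 nM in an assay on isolated protein for inhibition of kallikrein-5 (Homo sapiens); a lower number here means a stronger inhibitor, a higher number a weaker inhibitor. Among the three compounds measured so far it holds the lowest number: compound 1 `CCCCCCCCCCC/C(O)=C1/C(=O)[C@H](Cc2ccccc2)N(C(=O)OC(C)(C)C)C1=O` gives 3600 nM, and compound 2 `CCCCCCCCCCCCCCC/C(O)=C1/C(=O)[C@H](Cc2ccccc2)N(C(=O)OC(C)(C)C)C1=O` gives 12000 nM. The step of a 2.0-fold lower number from compound 1 to compound 3 (0.30 log units; within the scatter) stays within the scatter, whereas the step of a 6.7-fold lower number from compound 2 to compound 3 (0.82 log units; beyond the scatter) lies beyond it, so compound 3 separates clearly only from compound 2.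

Compound 4 `CCCCC/C=C\C/C=C\CCCCCCC/C(O)=C1/C(=O)[C@H](Cc2ccccc2)N(C(=O)OC(C)(C)C)C1=O` differs from compound 3 by hept-1-en-1-yl in place of heptyl on a saturated chain carbon bound to a double-bonded chain carbon. Among the measured compounds shown here, the one measured step that introduced a chain double bond, a 6.7-fold lower number from compound 2 to compound 3 (0.82 log units; beyond the scatter), also changed the chain length, and the step of a 3.3-fold higher number from compound 1 to compound 2 (0.52 log units; beyond the scatter) shows that length alone moves the number modestly. For the measured compounds named here, no measured step isolates a second double bond, so only a weak lowering, or no change beyond the scatter, is expected for the step of a 1.5-fold lower number from compound 3 to compound 4 (0.18 log units; within the scatter). Compound 4 is therefore estimated at 1200 nM in this assay, with a range from 500 nM to 3000 nM.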

Compound 4, half-maximal inhibitory concentration: 14000 nM
The estimate for compound 4 lay 12-fold (1.07 log units) below the measured number; the whole stated range lies below it.
By their numbers in this assay, from the lowest: compounds 3 and 1 (each within the scatter of the next); then compounds 2 and 4 (each within the scatter of the next).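

In this assay, hept-1-en-1-yl in place of heptyl on a saturated chain carbon bound to a double-bonded chain carbon gives a 7.8-fold higher number from compound 3 to compound 4 (0.89 log units; beyond the scatter), so at this place the added double bond raises the number. Among the compounds shown here, this is the first step that isolates a chain double bond, since the carbon count of the group stays the same, whereas the earlier step that introduced one also changed the chain length. The step of a 1.2-fold higher number from compound 2 to compound 4 (0.07 log units; within the scatter) leaves compound 4 inseparable from compound 2, while the step of a 3.9-fold higher number from compound 1 to compound 4 (0.59 log units; beyond the scatter) separates it from compound 1.

The data shown give no reason for the rise. As far as these compounds go, it remains open how a third double bond, a triple bond or a carboxylic acid at the chain end would read in this assay.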